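From pyridin-3-yl to pyridin-4-yl on a carbonyl carbon

The compounds below may be only part of what the source reports. "The series", "measured", "known", "first", "only" and "open" are said of these compounds alone.

Values measured in a functional assay on MCF7 cells (Homo sapiens) for inhibition, read by MTT assay, with a stated time of 48 h (a higher number here means a weaker inhibitor of growth, a lower number a stronger inhibitor of growth), follow
Compound 1 `Cn1cc(C2CC(c3ccc(F)cc3)=NN2C(=O)c2cccnc2)c2cc(Br)ccc21` gives 480 nM
Compound 2 `Cn1cc(C2CC(c3ccc(Cl)cc3)=NN2C(=O)c2cccnc2)c2cc(Br)ccc21` gives 8100 nM
Compound 3 `COc1ccc(C2=NN(C(=O)c3cccnc3)C(c3cn(C)c4ccc(Br)cc34)C2)cc1OC` gives 1170 nM

Among these three, compound 3 sits in the middle, with compound 1 giving the lowest number and compound 2 the highest. The next compound to be tested is compound 4 `COc1ccc(C2=NN(C(=O)c3ccncc3)C(c3cn(C)c4ccc(Br)cc34)C2)cc1OC`, which puts pyridin-4-yl in place of pyridin-3-yl on a carbonyl carbon. The change is pyridin-4-yl in place of pyridin-3-yl on a carbonyl carbon and the two compounds have the same atoms, joined differently.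

Among the compounds with values here, compound 1, compound 2 and compound 3 all carry pyridin-3-yl, so no measured step touches this place. The measured steps change the substituted phenyl group instead. They run from a 2.4-fold higher number from compound 1 to compound 3 (0.39 log units; beyond the scatter) through a 6.9-fold lower number from compound 2 to compound 3 (0.84 log units; beyond the scatter) to a 17-fold higher number from compound 1 to compound 2 (1.23 log units; beyond the scatter), which is large. They show that a single change among these compounds can move the number well beyond the scatter, but they give neither a size nor a direction for this swap. The best starting guess is therefore the value of compound 3 itself, with a wide margin on both sides.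

In this assay the expected step is a 1.0-fold higher number from compound 3 to compound 4 (0.01 log units; within the scatter) and no direction is favoured. For compound 4 the estimate is 1200 nM, expected to lie between 400 nM and 3600 nM in four of five measurements.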

Compound 4, concentration for 50% growth inhibition: > 10000 nM
Compound 4: only a limit was reported; the forecaster's own chance of this, stated with the estimate: 3%; middle value at least 8.3-fold (0.92 log units) away from the limit.
By their numbers in this assay, from the lowest: compound 1; then compound 3; then compound 2. At a limit, above all of these: compound 4.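

Until now, all the measured compounds carried pyridin-3-yl on the carbonyl carbon, so nothing showed whether this part of the molecule mattered for growth inhibition in this assay. It clearly does: replacing pyridin-3-yl with pyridin-4-yl gives an at least 8.5-fold higher number from compound 3 to compound 4 (0.93 log units; beyond the scatter), although the two groups have the same atoms and the same counts of rings, donors and acceptors, and differ only in how those atoms are joined. The reading for compound 4 is a limit of the assay and not a number: the limit of > 10000 nM in this assay, at which 1 of the 4 values shown sits.

Going by these compounds, it remains open whether this swap would have a similar effect with the other groups on the carbon with a double bond to nitrogen, such as the 4-fluorophenyl group of compound 1, which gives 480 nM. Also unresolved is how pyridin-2-yl, a plain phenyl group or a carbonyl carrying a morpholine would behave at this place on the carbonyl carbon, and whether any of them would read closer to pyridin-3-yl or to pyridin-4-yl.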